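A few compounds are considered here, and "the series" means these few. Any claim that something is new, unique, unknown or untested is made for them only; others in the source may bear on it.

In a functional assay on KB cells (Homo sapiens) for antiproliferative activity, read by sulforhodamine B assay, with a stated time of 72 h (a higher number here means a weaker inhibitor, a lower number a stronger inhibitor), compound 3 (`COc1cc(/C=C2\CCC=CC2=O)cc(OC)c1`) gives 3630 nM as the highest of the three numbers. Compound 1 (`COc1cccc(/C=C2\CCC=CC2=O)c1`) at 1550 nM and compound 2 (`O=C1C=CCC/C1=C\c1ccc(OC(F)(F)F)cc1`) at 530 nM both stand lower. Compound 4 (`COc1cc(/C=C2\CCC=CC2=O)cc(OC)c1O`) differs from compound 3 by one change (hydroxy in place of hydrogen on an aromatic carbon) that puts hydroxy in place of hydrogen on an aromatic carbon, ortho to two methoxy groups. The nearest measured step is methoxy in place of hydrogen on an aromatic carbon (a 2.3-fold higher number from compound 1 to compound 3 (0.37 log units; beyond the scatter)) and it is modest. Within the data shown here, no measured compound carries hydroxy, so the direction stays open and no larger step is expected in this assay for this change. The expected step is small (a 1.0-fold lower number from compound 3 to compound 4 (0.02 log units; within the scatter)) and may stay within the scatter. For compound 4 the estimated value is 3500 nM with an expected range from 1200 nM to 10000 nM for this estimate.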

Compound 4, half-maximal inhibitory concentration: 1520 nM
Compound 4: middle estimate off by 2.3-fold (0.36 log units), on the high side, within the range that was stated.
By their numbers in this assay, from the lowest: compound 2; then compounds 4 and 1 (each within the scatter of the next); then compound 3.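

Hydroxy in place of hydrogen on this aromatic carbon, ortho to two methoxy groups, lowers the number in this assay, with a 2.4-fold lower number from compound 3 to compound 4 (0.38 log units; beyond the scatter). The earlier methoxy step went the other way, with a 2.3-fold higher number from compound 1 to compound 3 (0.37 log units; beyond the scatter), so added aromatic substituents in this series do not all raise the number. Nothing at hand bears on why the number moves.

Still open, from the compounds shown here alone, is whether an amine or fluorine at this carbon would match hydroxy. Also open, going by these compounds, is whether hydroxy would lower the number without the two methoxy groups.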